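A few compounds are considered here, and "the series" means these few. Any claim that something is new, unique, unknown or untested is made for them only; others in the source may bear on it.

Within the data shown here, in an assay on isolated protein for inhibition of cyclin-dependent kinase 2-associated protein 1 (Homo sapiens) (a higher number here means a weaker inhibitor, a lower number a stronger inhibitor), compound 1 `CN(C)c1ccc(-c2cc(C(=O)N[C@H]3CCCNC3)c(NC(N)=O)s2)cc1` gives 8400 nM, the lowest of the two numbers measured so far. Compound 2 `NC(=O)Nc1sc(-c2ccc(C(=O)N3CCCCC3)cc2)cc1C(=O)N[C@H]1CCCNC1` gives 10800 nM in this assay, and the step of a 1.3-fold higher number from compound 1 to compound 2 (0.11 log units; within the scatter) falls within the scatter, so the two compounds cannot be ordered. Compound 3 `NC(=O)Nc1sc(-c2ccc(Cl)cc2)cc1C(=O)N[C@H]1CCCNC1` has not yet been measured; it differs from compound 1 as follows: chloro in place of dimethylamino on an aromatic carbon. Among the measured compounds shown here, the only measured step that bears on this position is the one from compound 1 to compound 2, which exchanged the same dimethylamino group on the same aromatic carbon and moved the number only within the scatter. On that basis the expected step of a 1.1-fold higher number from compound 1 to compound 3 (0.03 log units; within the scatter) is small, with no clear direction beyond the scatter. The estimate for compound 3 in this assay is therefore 9000 nM, expected to lie between 3000 nM and 30000 nM.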

Compound 3, half-maximal inhibitory concentration: 3700 nM
The estimate for compound 3 lay 2.4-fold (0.39 log units) above the measured number; the range from low to high includes it.
By their numbers in this assay, from the lowest: compound 3; then compounds 1 and 2 (each within the scatter of the next).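

The aromatic carbon does respond to the group it carries: in this assay chloro in place of dimethylamino gives a 2.3-fold lower number from compound 1 to compound 3 (0.36 log units; beyond the scatter) and chloro in place of (piperidin-1-yl)carbonyl gives a 2.9-fold lower number from compound 2 to compound 3 (0.47 log units; beyond the scatter) as modest changes beyond the scatter. The earlier exchange of dimethylamino for (piperidin-1-yl)carbonyl had left the two compounds unordered, whereas compound 3 now stands apart from both as the lowest of the three. Nothing measured here gives a reason for this difference.

The compounds shown leave open whether the lower number belongs to chloro alone or also comes with fluoro, bromo or methyl on that aromatic carbon. They also leave open whether a plain hydrogen there would read like chloro or like dimethylamino, and whether the step keeps its size when the shared core changes elsewhere.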